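This account rests on a few compounds, and the source may have more. Where it says the series, first, only, none or still open, it means among the compounds named here.

Measured compounds in a functional assay on cells (Leukemia cell, Homo sapiens) for cytotoxicity, read by sulforhodamine B assay, with a stated time of 48 h; a lower number here means a stronger inhibitor of growth, a higher number a weaker inhibitor of growth:
- compound 1, `COc1ccc(OC)c(-c2cc(-c3ccc(Cl)cc3)nn2-c2ccc(S(=O)(=O)NC(C)=O)cc2)c1`: 50100 nM
- compound 2, `Oc1ccc(O)c(-c2cc(-c3ccccc3)nn2-c2ccccc2)c1`: 100000 nM
- compound 3, `Oc1ccc(O)c(-c2cc(-c3ccc(Cl)cc3)nn2-c2ccccc2)c1`: 49700 nM

Compound 2 gives the highest number of the three, but its gap to compound 1 and to compound 3 is in each case within the scatter, so the three sit together. Within the data shown here, the one single-place step available is a 2.0-fold lower number from compound 2 to compound 3 (0.30 log units; within the scatter), and it concerns the chloro group, not the change considered here.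

Compound 4, `CC(=O)NS(=O)(=O)c1ccc(-n2nc(-c3ccccc3)cc2-c2cc(O)ccc2O)cc1`, is not yet measured. Against compound 2 the change is acetylsulfamoyl in place of hydrogen on an aromatic carbon. Among the measured compounds shown here, no measured pair isolates an acetylsulfamoyl group, so no step bears directly on it. Compound 1 carries the acetylsulfamoyl group alongside a chloro group and two methoxy groups, and compound 3 carries the chloro group with two hydroxy groups. Compound 1 gives 50100 nM. Compound 3 gives 49700 nM. These two values sit close together, which gives no sign that the acetylsulfamoyl group moves the number by itself.

With nothing in the series pointing either way, the step expected is a 1.4-fold lower number from compound 2 to compound 4 (0.15 log units; within the scatter), that is, none beyond the scatter. The estimate for compound 4 is 70000 nM, with a range from 25000 nM to 200000 nM.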

Compound 4, concentration for total growth inhibition: 100000 nM
Estimate against measurement, compound 4: 1.4-fold (0.15 log units) below, within the range that was stated.
By their numbers in this assay, from the lowest: compounds 3, 1, 2 and 4 (each within the scatter of the next).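

In this assay, among these compounds, the acetylsulfamoyl group now stands as the only change, on an aromatic carbon of a six-membered aromatic ring of carbon only, para to a large group, and the pair gives no change at the digits printed from compound 2 to compound 4 (within the scatter). Until now the group appeared only in compound 1, together with a chloro group and two methoxy groups, so its own contribution could not be read; on the core of compound 2, putting it in place of hydrogen leaves the number where it was, within the scatter. Nothing measured on these compounds gives a reason for this result.

Going by these compounds, it remains open whether the acetylsulfamoyl group would also leave the number unchanged on the core of compound 3, which carries the chloro group, or on a core with two methoxy groups, such as that of compound 1. Also open, on these data alone, is whether a different group at this position, such as a carboxylic acid, an amine or a sulfamoyl group without the acetyl part, would shift the number beyond the scatter.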